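The compounds below may be only part of what the source reports. "The series", "measured", "known", "first", "only" and "open" are said of these compounds alone.

In a functional assay on HeLa cells (Homo sapiens) for antiproliferative activity, read by MTT assay, with a stated time of 48 h (on this read-out lower numbers stand for stronger inhibition of growth and higher numbers for weaker inhibition of growth), compound 3 (`CCOc1cc(NC(=O)CCCCCC(=O)Nc2cc(-c3ccc(C)s3)ccc2N)cc2c1OCC([N+](=O)[O-])=C2`) gives > 20000 nM, which is a limit and not a number. Going by these compounds, compound 3 therefore stands at the limit of > 20000 nM in this assay, at which 1 of the 3 values shown sits, and its true position on the scale remains open. Compound 1 (`CCOc1cc(NC(=O)CCCCCC(=O)Nc2cc(-c3ccccc3)ccc2N)cc2c1OCC([N+](=O)[O-])=C2`) gives 19800 nM, and compound 2 (`CCOc1cc(NC(=O)CCCCC(=O)Nc2ccccc2N)cc2c1OCC([N+](=O)[O-])=C2`) gives 13100 nM, two values within the usual scatter of each other.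

Compound 4 (`CCOc1cc(NC(=O)CCCCCC(=O)Nc2ccccc2N)cc2c1OCC([N+](=O)[O-])=C2`) differs from compound 3 in one place: hydrogen in place of 5-methylthiophen-2-yl on an aromatic carbon. In words, hydrogen takes the place of 5-methylthiophen-2-yl on an aromatic carbon. For the measured compounds named here, the one measured step at this carbon is a number no lower from compound 1 to compound 3 (the limit leaves the size open), and its size cannot be read, so it gives only weak guidance. Better guidance comes from compound 2, which also carries hydrogen on that carbon and gives 13100 nM.

A modest move toward a lower number, meaning stronger inhibition of growth, is therefore expected for an at least 1.6-fold lower number from compound 3 to compound 4 (0.22 log units; that floor lies within the scatter). For compound 4 the estimated value is 12000 nM, with an expected range from 6000 nM to 20000 nM.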

Compound 4, concentration for 50% growth inhibition: 14900 nM
Compound 4: the middle estimate sits 1.2-fold (0.09 log units) below what was measured; measured number inside the range.
By their numbers in this assay, from the lowest: compounds 2, 4 and 1 (each within the scatter of the next). At a limit, above all of these: compound 3.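

In this assay, swapping phenyl for hydrogen on this aromatic carbon, para to an amino group, gives a 1.3-fold lower number from compound 1 to compound 4 (0.12 log units; within the scatter), and the change at the saturated chain carbon, ((2-aminophenyl)carbamoyl)methyl in place of (2-aminophenyl)carbamoyl, gives a 1.1-fold higher number from compound 2 to compound 4 (0.06 log units; within the scatter), so neither change moves the number beyond the scatter. Replacing 5-methylthiophen-2-yl with hydrogen at the same aromatic carbon gives an at least 1.3-fold lower number from compound 3 to compound 4 (0.12 log units; that floor lies within the scatter), so these compounds do not show that 5-methylthiophen-2-yl differs from hydrogen beyond the scatter. Compound 3 remains a limit and not a number, so the true size of this step stays unknown: the limit of > 20000 nM in this assay, at which 1 of the 4 values shown sits.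

Still open, going by these compounds, is whether any change at either place can move the number beyond the scatter. An amine or a carboxylic acid on this aromatic carbon, or a longer chain, would test this.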